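A Methyl Step Carried Over to a Second Core

A few compounds are considered here, and "the series" means these few. Any claim that something is new, unique, unknown or untested is made for them only; others in the source may bear on it.

The study centres on a small set of cyclic ureas examined in an assay on RBL-1 cells for inhibition of Polyunsaturated fatty acid 5-lipoxygenase (Rattus norvegicus); a higher number here means a weaker inhibitor, a lower number a stronger inhibitor. Compound 1 `O=C1NCCN(c2cccc(F)c2)N1` gives 19000 nM in this assay. Compound 2 `CC1CN(c2cccc(F)c2)NC(=O)N1` carries a single alteration relative to compound 1, namely (methyl in place of hydrogen on a saturated ring carbon), and in this assay compound 2 gives 6300 nM. That alteration produced a 3.0-fold lower number from compound 1 to compound 2 (0.48 log units; beyond the scatter).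

Compound 3 `O=C1NCCN(c2cccc(Br)n2)N1` rests on a different core; the difference between the core of compound 1 and the core of compound 3 is not broken down here. In this assay compound 3 gives 3500 nM. Set against compound 2, the number for compound 3 lies within the usual scatter, so the two cannot be ordered on this evidence, while the gap to compound 1 is beyond the scatter.

Compound 4 `CC1CN(c2cccc(Br)n2)NC(=O)N1` has not yet been measured. It stands to compound 3 exactly as compound 2 stands to compound 1: the alteration is methyl in place of hydrogen on a saturated ring carbon, and the surroundings of the place are the same in both cases, so this is the same change made a second time. The expectation is that the step from compound 3 to compound 4 will be a 2.9-fold lower number from compound 3 to compound 4 (0.46 log units; beyond the scatter), placed beside the earlier 3.0-fold lower number from compound 1 to compound 2 (0.48 log units; beyond the scatter); this rests only on that one precedent, and a single precedent is thin support. Compound 4 is therefore expected to give about 1200 nM in this assay, with the estimate lying between 450 nM and 3500 nM.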

Compound 4, half-maximal inhibitory concentration: 2400 nM
Beside the measured number, compound 4's estimate is 2.0-fold (0.30 log units) below it; low and high end bracket the measured number.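

In this assay, methyl in place of hydrogen on a saturated ring carbon of the core of compound 3 gave a 1.5-fold lower number from compound 3 to compound 4 (0.16 log units; within the scatter), so on this core the change cannot be told apart from the spread of repeated measurements. Set beside the first case, the two steps do not differ on this evidence: the same change on two cores in this assay, a 3.0-fold lower number (0.48 log units; beyond the scatter) from compound 1 to compound 2 and a 1.5-fold lower number (0.16 log units; within the scatter) from compound 3 to compound 4, 2.1-fold (0.32 log units) apart, within the scatter of two such steps This gives no sign that the change behaves differently on the two cores, but it does not show that the change carries over with its full size, since only the first step is beyond the scatter, and two pairs of compounds are too few to support a general rule for the series.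

The compounds shown leave open what would happen with something other than methyl on that saturated ring carbon, such as an ethyl group, a longer chain, an amine or a carboxylic acid. They also leave open whether the methyl step would stand clear of the scatter on a third core, or whether the larger step seen on the core of compound 1 is the exception.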